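From trifluoromethyl to methylsulfonyl on compound 2

This account rests on a few compounds, and the source may have more. Where it says the series, first, only, none or still open, it means among the compounds named here.

Measured in a functional assay on J774 cells (Mus musculus) for cytotoxicity, read by resazurin assay, with a stated time of 72 h; on this read-out lower numbers stand for stronger inhibition and higher numbers for weaker inhibition:
Compound 1 `O=S(=O)(Nc1ccc(CO)c(CO)c1)c1ccc(-c2ccc(F)cc2)cc1` gives 1000 nM
Compound 2 `O=S(=O)(Nc1cccc(CO)c1)c1ccc(-c2ccc(C(F)(F)F)cc2)cc1` gives 2500 nM

Of these two, compound 2 holds the higher number, and the gap down to compound 1 lies beyond the usual scatter. The two compounds differ in more than one place, so the gap cannot be tied to any single change.

Compound 3 `CS(=O)(=O)c1ccc(-c2ccc(S(=O)(=O)Nc3cccc(CO)c3)cc2)cc1` keeps the core of compound 2 but carries methylsulfonyl in place of trifluoromethyl on an aromatic carbon, para to a large group (methylsulfonyl in place of trifluoromethyl on an aromatic carbon). Among the compounds with values here, no measured pair shows this exchange, so the data do not fix its size. In this assay, a modest move towards a higher number is expected, only slightly beyond the scatter. The expected change is a 2.0-fold higher number from compound 2 to compound 3 (0.30 log units; within the scatter). For compound 3 the estimated value is 5000 nM, with an expected range of 1800 nM to 15000 nM.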

Compound 3, half-maximal inhibitory concentration: > 5000 nM
Compound 3: only a limit was reported (the forecaster's own chance of this, stated with the estimate: 15%); the middle value lies on the limit itself.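

In this assay, compound 3 gives > 5000 nM, which is a limit of the assay and not a number. Methylsulfonyl in place of trifluoromethyl on an aromatic carbon, para to a large group, is the first change in a single place that can be read here, and it gives an at least 2.0-fold higher number from compound 2 to compound 3 (0.30 log units; that floor lies within the scatter). The full size of this step stays unknown because the result rests on a limit: the limit of > 5000 nM in this assay, at which 1 of the 3 values shown sits.

On these data alone, whether an amine or a carboxylic acid on the same aromatic carbon would move the number the same way remains open. Also open, as far as these compounds go, is how the gap between compound 1 and compound 2 divides among the places in which those two compounds differ.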